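The source may report more compounds than this note shows. Statements on the series, on what has been measured and on what is new or still open speak of the compounds shown alone.

Compound 1 `CN1CCN(c2ccc(-c3cc4c(N5CCN(S(=O)(=O)/C=C/c6ccccc6)CC5)ncnc4s3)cc2)CC1`: 5900 nM
Compound 2 `CCS(=O)(=O)N1CCN(c2ncnc3sc(-c4ccc(N5CCN(C)CC5)cc4)cc23)CC1`: 7330 nM
Compound 3 `CCCNC(=O)N1CCN(c2ncnc3sc(-c4ccc(N5CCN(C)CC5)cc4)cc23)CC1`: 8330 nM

All three values come from a functional assay on MDA-MB-231 cells (Homo sapiens) for antiproliferative activity, read by MTT assay, with a stated time of 48 h (on this read-out higher numbers stand for weaker inhibition and lower numbers for stronger inhibition), and they lie close together. Compound 3 stands at 8330 nM, within the scatter of both other compounds, so the three show no order in this assay.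

The next compound is compound 4 `CN1CCN(c2ccc(-c3cc4c(N5CCN(C(=O)Nc6ccccc6)CC5)ncnc4s3)cc2)CC1`. The change is phenyl in place of propyl on an amide-type nitrogen; in words, phenyl in place of propyl on an amide-type nitrogen. Going by the values given here, no measured step makes this exact swap, so the evidence is indirect. The closest case of a group with an aromatic ring giving way to a short chain is a 1.2-fold higher number from compound 1 to compound 2 (0.09 log units; within the scatter), where the sulfonyl group bears ethyl instead of 2-phenylethenyl. The two steps that alter the same ring nitrogen more broadly are a 1.4-fold higher number from compound 1 to compound 3 (0.15 log units; within the scatter) and a 1.1-fold higher number from compound 2 to compound 3 (0.06 log units; within the scatter). All three stay within the scatter, which gives no ground for expecting a direction here. The data hold no direct test of a phenyl on this nitrogen, so the range is kept wide.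

The estimate implies a 1.2-fold lower number from compound 3 to compound 4 (0.08 log units; within the scatter), an expected step no larger than the scatter. The expected value for compound 4 is 7000 nM, with an estimated range from 3000 nM to 16000 nM.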

Compound 4, half-maximal inhibitory concentration: 7590 nM
Estimate against measurement, compound 4: 1.1-fold (0.04 log units) below; measured number inside the range.
By their numbers in this assay, from the lowest: compounds 1, 2, 4 and 3 (each within the scatter of the next).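

In this assay the propyl-to-phenyl swap on the amide-type nitrogen now has a direct reading, a 1.1-fold lower number from compound 3 to compound 4 (0.04 log units; within the scatter), so putting an aromatic ring of carbon in place of this short chain leaves the number within the scatter. Phenylcarbamoyl also stays within the scatter of both sulfonyl groups on the same amine nitrogen in a ring, with a 1.0-fold higher number from compound 2 to compound 4 (0.02 log units; within the scatter) and a 1.3-fold higher number from compound 1 to compound 4 (0.11 log units; within the scatter), so across these four compounds neither the carbamoyl-or-sulfonyl link nor an aromatic ring on that link separates the values, and none of the four goes against this. No measurement shown here offers an account of why these values lie so close together.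

As far as these compounds go, it remains open whether a phenyl carrying an amine or a carboxylic acid, or a longer chain such as octyl on the amide-type nitrogen, would give a step beyond the scatter. All four compounds also share the rest of the structure, so whether this nitrogen's substituent would matter more alongside a different group elsewhere on the shared core cannot be told from them.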